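Hydrazone adenosine analogues: aryl variation at the para position

The compounds below may be only part of what the source reports. "The series", "measured", "known", "first", "only" and "open" are said of these compounds alone.

Measured so far:
compound 1, `Nc1nc(N/N=C/c2ccc(-c3ccccn3)cc2)nc2c1ncn2[C@@H]1O[C@H](CO)[C@@H](O)[C@H]1O` — 7540 nM
compound 2, `Nc1nc(N/N=C/c2ccc(N(c3ccccc3)c3ccccc3)cc2)nc2c1ncn2[C@@H]1O[C@H](CO)[C@@H](O)[C@H]1O` — > 10000 nM

In an assay on CHO-K1 cells for displacement of a labelled ligand from adenosine receptor A1 (Homo sapiens), read by scintillation counting, with a stated time of 60 min (on this read-out lower numbers stand for stronger inhibition and higher numbers for weaker inhibition), compound 1 gives 7540 nM. For compound 2 this assay records only a limit, > 10000 nM, and no number. Among the measured compounds shown here, compound 1 therefore carries the single numeric value; the other entry is the limit (the limit of > 10000 nM in this assay, at which 1 of the 2 values shown sits), so no step between two measured numbers can be drawn.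

The next compound, compound 3, `Nc1nc(N/N=C/c2ccc(-n3ccnc3)cc2)nc2c1ncn2[C@@H]1O[C@H](CO)[C@@H](O)[C@H]1O`, differs from compound 1 in one place: 1H-imidazol-1-yl in place of pyridin-2-yl on an aromatic carbon. For the measured compounds named here, the data show no measured step that would tell how this assay answers such a change, and no value for compound 2 that could be set against compound 1 as a number. The step from compound 1 to compound 3 is expected to be small, no larger than the usual scatter, in either direction, giving a 1.0-fold lower number from compound 1 to compound 3 (0.00 log units; within the scatter). On that basis compound 3 is estimated at 7500 nM, within a range of 2500 nM to 22000 nM in this assay.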

Compound 3, inhibition constant: > 10000 nM
Compound 3 ended at the assay's limit; the forecaster's own chance of this, stated with the estimate: 30%; middle value at least 1.3-fold (0.12 log units) from the limit.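

In this assay, 1H-imidazol-1-yl in place of pyridin-2-yl on this aromatic carbon gives an at least 1.3-fold higher number from compound 1 to compound 3 (0.12 log units; that floor lies within the scatter). Among the compounds shown here, this is the first step that can be read at this position, but it has only a floor, so its full size remains unknown. For the compounds shown here, compound 3 records a limit, > 10000 nM, and not a number, which leaves compound 1 as the only compound with a numeric value and puts most of the series at the limit: the limit of > 10000 nM in this assay, at which 2 of the 3 values shown sit.

Steps involving compound 2 cannot be read, and neither limit shows how much weaker compound 2 or compound 3 may be. From the compounds shown here alone, whether an amine or a carboxylic acid in place of pyridin-2-yl on this aromatic carbon would give a lower number remains open.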